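The source may hold more compounds than are shown below. What is called first, only, known or untested is meant among the compounds shown, and "the series" means these compounds.

In a functional assay on MIA PaCa-2 cells (Homo sapiens) for inhibition, read by MTT assay, with a stated time of 72 h, tested at 50 uM (a higher number here means more inhibition of growth at the concentration tested, a lower number less inhibition of growth), compound 1 `C=CCc1ccc(OCc2cn(-c3ccc(C#N)cc3)nn2)c(O)c1` gives 45.9% and compound 2 `C=CCc1ccc(OCc2cn(-c3cc(OC)c(OC)c(OC)c3)nn2)c(O)c1` gives 49.8%, two values within the usual scatter of each other. Compound 3 `C=CCc1ccc(OCc2cn(-c3ccc(Br)cc3)nn2)c(O)c1` has not yet been measured. It keeps the core of compound 1 and alters one group: bromo in place of cyano on an aromatic carbon, so 4-cyanophenyl becomes 4-bromophenyl. Within the data shown here, no measured pair shows this swap, so the estimated step in this assay, a number 4.1 percentage points higher from compound 1 to compound 3 (within the scatter), is expected to stay within the scatter. Compound 3 is expected to give 50%, within an estimated range of 36% to 64%.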

Compound 3, percent growth inhibition at one concentration: 47.3%
Compound 3: the middle estimate sits 2.7 percentage points above what was measured; the range from low to high includes it.
By their numbers in this assay, from the lowest: compounds 1, 3 and 2 (each within the scatter of the next).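

Among these compounds, the step of a number 1.4 percentage points higher from compound 1 to compound 3 (within the scatter) in this assay is the first comparison here between two compounds that differ in one place: bromo in place of cyano on an aromatic carbon, para to a large group. At this position, a single bromine atom and a cyano group with its triple bond and hydrogen-bond acceptor cannot be told apart in this read-out. No measurement shown accounts for this result.

As far as these compounds go, whether an amine, a carboxylic acid or a longer chain at this position would also stay within the scatter remains open.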